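Series notes: pyrrolidinyl-pyrimidine aryl ethers in a cell assay

The source may hold more compounds than are shown below. What is called first, only, known or untested is meant among the compounds shown, and "the series" means these compounds.

Measured so far:
compound 1 `CN(c1ccc(Oc2ncnc3ccsc23)cc1)c1nccc(N2CCCC2)n1` — 63.6%
compound 2 `c1cc(N2CCCC2)nc(Nc2ccc(Oc3ncnc4sccc34)cc2)n1` — 54.4%

In a functional assay on HCT-116 cells (Homo sapiens) for inhibition, read by MTT assay, with a stated time of 72 h, tested at 20 uM (on this read-out lower numbers stand for less inhibition and higher numbers for more inhibition at the one concentration tested (going by the name of the read-out)), compound 1 gives 63.6% and compound 2 gives 54.4%. Compound 2 has the lower of the two numbers, but the gap to compound 1 is within the scatter, so the two are not ordered. Among the measured compounds shown here, compound 1 and compound 2 differ in more than one place, so no single step is computed between them.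

Compound 3 `c1cc(N2CCCC2)nc(Nc2ccc(Oc3ncnc4ccsc34)cc2)n1` is the next compound, not yet measured. It differs from compound 2 only in the bicyclic group on the ether oxygen (a group of 9 heavy atoms (6 carbon, 2 nitrogen, 1 sulfur; one five-membered aromatic ring with 1 hetero atom, one six-membered aromatic ring with 2 hetero atoms) in place of a group of 9 heavy atoms (6 carbon, 2 nitrogen, 1 sulfur; one five-membered aromatic ring with 1 hetero atom, one six-membered aromatic ring with 2 hetero atoms), on an oxygen on an aromatic ring). The two groups are the same atoms joined differently, and the rest of the molecule is unchanged.

For the measured compounds named here, no measured pair isolates this change, so the expected step from compound 2 to compound 3 in this assay is small, of either direction, and not clearly beyond the scatter: a number 2.6 percentage points higher from compound 2 to compound 3 (within the scatter) is the expected step. Compound 3 is therefore estimated at 57%, in the range 40% to 74%.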

Compound 3, a percentage reported as inhibition, at one concentration (the size of the read-out at that concentration, not a potency): 22.2%
Beside the measured number, compound 3's estimate is 34.8 percentage points above it, outside the stated range (below it).
By their numbers in this assay, from the lowest: compound 3; then compounds 2 and 1 (each within the scatter of the next).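

The arrangement of the same atoms in the bicyclic group on the ether oxygen matters in this assay: with the rest of the molecule unchanged, the result is a number 32.2 percentage points lower from compound 2 to compound 3 (beyond the scatter). With the bicyclic group of compound 3 held fixed, hydrogen in place of methyl on a nitrogen on an aromatic ring also gives a large change, a number 41.4 percentage points lower from compound 1 to compound 3 (beyond the scatter). Nothing measured here accounts for either step.

Going by these compounds, compound 1 and compound 2 differ in more than one place, and whether the methyl step holds with the bicyclic group of compound 2 stays open. Equally open, on these data alone, is what an ethyl group or a longer chain on that nitrogen would give in this assay.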